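The source may hold more compounds than are shown below. What is called first, only, known or untested is meant among the compounds shown, and "the series" means these compounds.

Measured in a functional assay on MCF7 cells (Homo sapiens) for cytotoxicity, read by MTT assay, with a stated time of 72 h; on this read-out lower numbers stand for stronger inhibition and higher numbers for weaker inhibition:

Compound 1, `Cc1ccc(-c2ccc(C)n2-c2ccc(-c3nc4ccccc4s3)cc2)cc1`, gives 3100 nM.
Compound 2, `COc1ccc2nc(-c3ccc(-n4c(C)ccc4-c4ccc(C)cc4)cc3)sc2c1`, gives 2850 nM.

Compound 2 has the lowest of the two numbers, but its nearest neighbour is compound 1, and the step of a 1.1-fold lower number from compound 1 to compound 2 (0.04 log units; within the scatter) shows the two cannot be told apart. Compound 3, `COc1ccc(-c2ccc(C)n2-c2ccc(-c3nc4ccc(OC)cc4s3)cc2)cc1`, is not yet measured. It differs from compound 2 by methoxy in place of methyl on an aromatic carbon, a change on the ring of compound 2 that carries the methyl group.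

Among the compounds with values here, only one measured step bears on this. From compound 1 to compound 2 a methoxy group entered on the shared core in place of hydrogen, and the step of a 1.1-fold lower number from compound 1 to compound 2 (0.04 log units; within the scatter) stayed within the scatter. Within the data shown here, that step put the methoxy on a different part of the molecule, so it is a loose guide at best, but it is the only evidence that a methoxy group changes the numbers in this assay little, and nothing else in the data points to a step beyond the scatter.

On that basis compound 3 is expected to give 2800 nM, within 1200 nM to 6500 nM, which means an expected step of a 1.0-fold lower number from compound 2 to compound 3 (0.01 log units; within the scatter), no larger than the scatter.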

Compound 3, half-maximal inhibitory concentration: 4830 nM
The estimate for compound 3 lay 1.7-fold (0.24 log units) below the measured number; the measured number falls inside the stated range.
By their numbers in this assay, from the lowest: compounds 2, 1 and 3 (each within the scatter of the next).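

In this assay, the 4-methylphenyl group of compound 2 becomes the 4-methoxyphenyl group of compound 3, the first change shown on this ring, and it gives a 1.7-fold higher number from compound 2 to compound 3 (0.23 log units; within the scatter) on this read-out. Methoxy in place of methyl at this position, para to a large group, therefore does not separate the two compounds, although the step is wider than a 1.1-fold lower number from compound 1 to compound 2 (0.04 log units; within the scatter) on the shared core, which also stays within the scatter. Compound 3 carries methoxy in both places, and its number still cannot be told apart from that of compound 2, so neither site has yet shown a step beyond the scatter. No measurement offered here explains the numbers of these compounds.

The compounds shown leave open whether any group at this position can move the number beyond the scatter, since only methyl and methoxy stand there. An amine, a carboxylic acid or a longer chain such as ethoxy in that place would test this, and until such a step is seen, the tolerance of this position remains known for these two groups only.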